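A Dithiolethione Swap on a Benzyl Amide Scaffold

The source may report more compounds than this note shows. Statements on the series, on what has been measured and on what is new or still open speak of the compounds shown alone.

Compound 1, `COc1cc(CNC(=O)CCCC/C=C/C(C)C)ccc1OCCCCOc1ccc(C(N)=S)cc1`, gives 49800 nM in a functional assay on MCF7 cells (Homo sapiens) for antiproliferative activity, read by MTT assay, with a stated time of 48 h; on this read-out lower numbers stand for stronger inhibition and higher numbers for weaker inhibition.
Compound 2, `COc1cc(CNC(=O)CCCC/C=C/C(C)C)ccc1OC(=O)CCC(=O)Oc1ccc(-c2cc(=S)ss2)cc1`, gives 2120 nM in this assay.
Compound 3, `COc1cc(CNC(=O)CCCC/C=C/C(C)C)ccc1OC(=O)CCC(=O)Oc1ccc(C(N)=S)cc1`, gives only a limit in this assay, namely > 50000 nM.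

The three measured compounds share a benzyl amide core carrying an unsaturated acyl chain, but they part in two ways. Compound 3 and compound 2 differ in one place: a group of 6 heavy atoms (3 carbon, 3 sulfur; one five-membered aromatic ring with 2 hetero atoms) in place of a group of 3 heavy atoms (1 carbon, 1 nitrogen, 1 sulfur; no ring), on an aromatic carbon. The step is an at least 23-fold lower number from compound 3 to compound 2 (1.37 log units; beyond the scatter). Its size cannot be set exactly, since the value of compound 3 is the limit of > 50000 nM in this assay, at which 1 of the 3 values shown sits. How the core of compound 1 differs from the core of compound 3 is not broken down here.

Compound 4, `COc1cc(CNC(=O)CCCC/C=C/C(C)C)ccc1OCCCCOc1ccc(-c2cc(=S)ss2)cc1`, has not yet been measured in this assay. It stands to compound 1 as compound 2 stands to compound 3: a group of 6 heavy atoms (3 carbon, 3 sulfur; one five-membered aromatic ring with 2 hetero atoms) in place of a group of 3 heavy atoms (1 carbon, 1 nitrogen, 1 sulfur; no ring), on an aromatic carbon. The place around the change is the same in both pairs, so this is the same change. On that ground, a step of about a 20-fold lower number from compound 1 to compound 4 (1.30 log units; beyond the scatter) in this assay is expected, resting on the measured pair of compound 3 and compound 2 with an at least 23-fold lower number from compound 3 to compound 2 (1.37 log units; beyond the scatter) and on compound 1 with 49800 nM. The estimate for compound 4 is therefore 2500 nM, expected to lie between 700 nM and 9000 nM. Within the data shown here, only one measured pair supports this, so the expectation is held loosely.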

Compound 4, half-maximal inhibitory concentration: 36400 nM
Compound 4: middle estimate off by 15-fold (1.16 log units), on the low side; the measured number lies above the stated range.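

On the core of compound 1, putting the group with the five-membered aromatic ring with 2 hetero atoms in place of the group of 3 heavy atoms gives a 1.4-fold lower number from compound 1 to compound 4 (0.14 log units; within the scatter) in this assay, so the large step seen on the other core does not carry over in size: the same change on two cores in this assay, an at least 23-fold lower number (1.37 log units; beyond the scatter) from compound 3 to compound 2 and a 1.4-fold lower number (0.14 log units; within the scatter) from compound 1 to compound 4, at least 17-fold (1.23 log units) apart, beyond the scatter of two such steps. Compound 3 has only a limit, > 50000 nM, so the earlier step has no exact size. The two pairs show that the effect of this change in this assay depends on the core it is made on, but they do not show which feature of the cores is responsible, and with one pair per core they offer no general rule for the series.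

On these data alone, it remains open whether the same change on a core with a longer chain, or with an amide in the connecting chain, would follow the large step or the step within the scatter. Also open, as far as these compounds go, is how an amine or a carboxylic acid, placed on the aromatic carbon that carries the changed group, would behave on either core in this assay.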